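Swapping a Saturated Amine for Anilino on the Indazole Core

A few compounds are considered here, and "the series" means these few. Any claim that something is new, unique, unknown or untested is made for them only; others in the source may bear on it.

Of the compounds shown here, three have been measured in an assay on isolated protein for inhibition of tyrosine-protein kinase receptor UFO (Homo sapiens), with a stated time of 1.5 h; on this read-out higher numbers stand for weaker inhibition and lower numbers for stronger inhibition. Compound 1 `O=C1CC(c2ccccc2)=NN1` gives 13000 nM, and compound 3 `Cn1cc(-c2n[nH]c3cc(-c4ccccc4)ccc23)cn1` gives 12300 nM. Compound 2 `CNC1CCN(c2ccc3[nH]nc(-c4cnn(C)c4)c3c2)C1` gives 432000 nM, the highest of the three numbers and well beyond the scatter from both others, so it is the weakest inhibitor shown. Compound 4 `Cn1cc(-c2n[nH]c3ccc(Nc4ccccc4)cc23)cn1` differs from compound 2 by one change: anilino in place of 3-(methylamino)pyrrolidin-1-yl on an aromatic carbon. Among the compounds with values here, no measured pair maps this exact change, but compound 3, which carries a phenyl group on the same shared core, reaches 12300 nM, far lower than compound 2. A large drop is therefore expected from compound 2 to compound 4, of about a 29-fold lower number from compound 2 to compound 4 (1.46 log units; beyond the scatter). Compound 4 is estimated at 15000 nM, within a range from 3000 nM to 80000 nM.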

Compound 4, half-maximal inhibitory concentration: 580 nM
Compound 4: the middle estimate sits 26-fold (1.41 log units) above what was measured; measured number outside the range, below it.
By their numbers in this assay, from the lowest: compound 4; then compounds 3 and 1 (each within the scatter of the next); then compound 2.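

In this assay, this position turns out to be very sensitive to the group it carries: anilino in place of 3-(methylamino)pyrrolidin-1-yl, with the same count of heavy atoms entering and leaving, gives a 740-fold lower number from compound 2 to compound 4 (2.87 log units; beyond the scatter). Within the data shown here, this is the first single change whose size can be read on the shared core. No measurement shown explains why the step is so large. Still open, going by these compounds, is whether the gain needs the nitrogen link of anilino or only its aromatic ring, and how a benzyl or a morpholine group would compare at this place.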